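The source may report more compounds than this note shows. Statements on the series, on what has been measured and on what is new or still open speak of the compounds shown alone.

Working notes on the series. Compound 1 `Cc1nc2c3ccccc3ccc2c2nc3c(ccc4ccccc43)c(-c3ccccc3S)c12` gives 4070 nM in a functional assay on AGS cells (Homo sapiens) for cytotoxicity, read by MTT assay, with a stated time of 48 h; a higher number here means a weaker inhibitor, a lower number a stronger inhibitor. Compound 2 `Cc1ccc(-c2c3ccc4ccccc4c3nc3c2c(C)nc2c4ccccc4ccc32)cc1` sits at the limit of this assay, > 80000 nM, which is a limit and not a number (the limit of > 80000 nM in this assay, at which 1 of the 3 values shown sits). Compound 3 `Cc1nc2c3ccccc3ccc2c2nc3c(ccc4ccccc43)c(-c3ccc(O)cc3)c12` gives 14200 nM in this assay, the highest of the two numbers in hand; the nearest is compound 1, and the step of a 3.5-fold higher number from compound 1 to compound 3 (0.54 log units; beyond the scatter) separates them. The other change at the same aromatic carbon runs an at least 19-fold higher number from compound 1 to compound 2 (1.29 log units; beyond the scatter), and the exchange of hydroxy for methyl runs an at least 5.6-fold lower number from compound 2 to compound 3 (0.75 log units; beyond the scatter).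

Compound 4 `Cc1nc2c3ccccc3ccc2c2nc3c(ccc4ccccc43)c(-c3cc(O)nc4ccccc34)c12` differs from compound 3 by 2-hydroxyquinolin-4-yl in place of 4-hydroxyphenyl on an aromatic carbon. The three measured steps all concern the group on this aromatic carbon and show that a change there moves this assay by a modest to large amount, with a hydroxy-bearing ring placed more favourably than a methyl-bearing one. Within the data shown here, no measured step tests a second ring fused to the hydroxy-bearing ring, so the direction is open; a step of about the size of a 3.5-fold higher number from compound 1 to compound 3 (0.54 log units; beyond the scatter) in either direction is expected. Compound 4 is estimated at 12000 nM, with a range of 3000 nM to 45000 nM, which means an expected step of a 1.2-fold lower number from compound 3 to compound 4 (0.07 log units; within the scatter).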

Compound 4, half-maximal inhibitory concentration: 15800 nM
Compound 4: middle estimate off by 1.3-fold (0.12 log units), on the low side; measured number inside the range.
By their numbers in this assay, from the lowest: compound 1; then compounds 3 and 4 (each within the scatter of the next). At a limit, above all of these: compound 2.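

Adding a second fused ring with a ring nitrogen to the hydroxy-bearing group leaves this assay within the scatter: a 1.1-fold higher number from compound 3 to compound 4 (0.05 log units; within the scatter). This position therefore accepts the larger 2-hydroxyquinolin-4-yl as readily as 4-hydroxyphenyl, and the 2-sulfanylphenyl group stays apart from it, with the step of a 3.9-fold higher number from compound 1 to compound 4 (0.59 log units; beyond the scatter). The remaining step, an at least 5.0-fold lower number from compound 2 to compound 4 (0.70 log units; beyond the scatter), is read against a limit and not a number: the limit of > 80000 nM in this assay, at which 1 of the 4 values shown sits.

The compounds shown leave open whether the gap to compound 1 belongs to the sulfanyl group itself or to its place on the ring, which 4-sulfanylphenyl or 2-hydroxyphenyl would separate. They also leave open how an amine or a carboxylic acid in place of the hydroxy group would read at this aromatic carbon.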